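From pyridin-4-yl to 1,3-benzothiazol-6-yl on a carbonyl carbon

This account rests on a few compounds, and the source may have more. Where it says the series, first, only, none or still open, it means among the compounds named here.

Compound 1 `CN(C(=O)c1cc(-c2ccccn2)[nH]n1)c1ccc(OCB2C=Cc3ccccc3N2)cc1`: 25 mL/min/kg
Compound 2 `CN(C(=O)c1ccncc1)c1ccc(OCB2C=Cc3ccccc3N2)cc1`: 115 mL/min/kg

In an ADME assay (liver) for metabolic stability, with Liver microsome (Rattus norvegicus) as the target, using microsomes (on this read-out higher numbers stand for fast clearance and lower numbers for slow clearance), compound 2 has the higher number of the two measured compounds at 115 mL/min/kg, while compound 1 gives 25 mL/min/kg. Compound 3 `CN(C(=O)c1ccc2ncsc2c1)c1ccc(OCB2C=Cc3ccccc3N2)cc1` has not yet been measured. It differs from compound 2 in one group: 1,3-benzothiazol-6-yl in place of pyridin-4-yl on a carbonyl carbon. In words, 1,3-benzothiazol-6-yl stands in place of pyridin-4-yl on a carbonyl carbon.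

Going by the values given here, one measured step bears on this change, at the same place: a 4.6-fold higher number from compound 1 to compound 2 (0.66 log units; beyond the scatter). There, pyridin-4-yl stands in place of 5-(pyridin-2-yl)-1H-pyrazol-3-yl, and the step is modest but beyond the scatter. The group entering compound 3 is not the group of compound 1, so this single step offers only a weak guide to direction and size. A small move toward lower numbers is therefore expected, one that may not exceed the scatter. The expected step is a 1.8-fold lower number from compound 2 to compound 3 (0.25 log units; within the scatter). Compound 3 is estimated at 65 mL/min/kg, with an expected range from 28 mL/min/kg to 150 mL/min/kg.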

Compound 3, clearance: 73.3 mL/min/kg
The estimate for compound 3 lay 1.1-fold (0.05 log units) below the measured number, and the stated range covers the measured number.
By their numbers in this assay, from the lowest: compound 1; then compounds 3 and 2 (each within the scatter of the next).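

In this assay, placing 1,3-benzothiazol-6-yl on the carbonyl carbon in place of pyridin-4-yl gives a 1.6-fold lower number from compound 2 to compound 3 (0.20 log units; within the scatter), so this larger group, with its five-membered and six-membered aromatic rings, cannot be told apart from the single pyridine ring on this read-out. The third group also shows that the earlier gap was not specific to pyridin-4-yl: 5-(pyridin-2-yl)-1H-pyrazol-3-yl stands apart from 1,3-benzothiazol-6-yl as well, with a 2.9-fold higher number from compound 1 to compound 3 (0.47 log units; beyond the scatter), a modest step beyond the scatter, alongside a 4.6-fold higher number from compound 1 to compound 2 (0.66 log units; beyond the scatter). Among these three compounds, then, the position responds to the group it carries, with compound 1 alone at the low end, but nothing measured here accounts for why that group differs from the other two.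

On these data alone, it remains open whether the low number of compound 1 would persist with a plain 1H-pyrazol-3-yl group lacking its pyridin-2-yl ring. Nor do these compounds show how an amine or a carboxylic acid on the same carbonyl carbon would read, or whether changes elsewhere in the shared core would alter these steps.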